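Two Measured Analogues and an Untested Bromophenyl Imine

A few compounds are considered here, and "the series" means these few. Any claim that something is new, unique, unknown or untested is made for them only; others in the source may bear on it.

Compound 1 `N#CCC(=O)N/N=C1\C(=O)Nc2ccc(S(=O)(=O)N3CCOCC3)cc21`: 10300 nM
Compound 2 `COc1ccc(-c2c(C#N)c(N)n(/N=C3\C(=O)Nc4ccc(S(=O)(=O)N5CCOCC5)cc43)c(=O)c2C#N)cc1`: 18100 nM

In a functional assay on HCT-116 cells (Homo sapiens) for cytotoxicity, read by sulforhodamine B assay, with a stated time of 24 h (on this read-out higher numbers stand for weaker inhibition and lower numbers for stronger inhibition), compound 1 gives 10300 nM, the lowest of the two numbers; compound 2 gives 18100 nM, which lies within the scatter of that value. Compound 3 `O=C1Nc2ccc(S(=O)(=O)N3CCOCC3)cc2/C1=N/c1ccc(Br)cc1` is not yet measured. It differs from compound 1 in one place: 4-bromophenyl in place of ((cyanomethyl)carbonyl)amino on a double-bonded nitrogen. Within the data shown here, no measured step of this kind exists here, so the direction is unknown; the step from compound 1 to compound 3 is expected to stay within the scatter, a 1.2-fold higher number from compound 1 to compound 3 (0.07 log units; within the scatter). Compound 3 is therefore estimated at 12000 nM, between 3000 nM and 50000 nM.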

Compound 3, half-maximal inhibitory concentration: 15300 nM
For compound 3 the middle estimate is 1.3-fold (0.11 log units) below the measured one, and the stated range covers the measured number.
By their numbers in this assay, from the lowest: compounds 1, 3 and 2 (each within the scatter of the next).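

In this assay, 4-bromophenyl in place of ((cyanomethyl)carbonyl)amino on the double-bonded nitrogen gives a 1.5-fold higher number from compound 1 to compound 3 (0.17 log units; within the scatter) and so makes no difference beyond the scatter. Among these compounds, this is the first single-place step at this position, and it shows that a six-membered aromatic ring of carbon only, with no hydrogen-bond donors or acceptors, can stand in place of the open chain on the shared core. Nothing at hand explains this result. Still open, from the compounds shown here alone, is whether an amine or a carboxylic acid in place of the bromine would keep the number within the scatter. A longer chain on the same nitrogen also remains an open case.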